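The source may report more compounds than this note shows. Statements on the series, on what has been measured and on what is new or still open speak of the compounds shown alone.

Measured in an ADME assay on Raji cells (Homo sapiens) for cytotoxicity, read by CellTiter-Glo and resazurin assay, with a stated time of 72 h (a lower number here means that less compound is needed, a higher number that more compound is needed for the effect), each of the three compounds reached only the limit of the assay:

Compound 1 `CC(=O)Nc1cccc(-c2ccc(C(=O)N(Cc3cccc(OCCCCCC(=O)O)c3)C(C)C)cc2)c1` gives > 26000 nM, a limit.
Compound 2 `CC(C)N(Cc1cccc(OCCCCCC(=O)O)c1)C(=O)c1ccc(-c2ccsc2)cc1` gives > 26000 nM, a limit.
Compound 3 `COc1ccc(F)c(-c2ccc(C(=O)N(Cc3cccc(OCCCCCC(=O)O)c3)C(C)C)cc2)c1` gives > 26000 nM, a limit.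

Compound 1 therefore stands nowhere on a scale of numbers but only at a limit, the same one at which every value here sits, as the limit of > 26000 nM in this assay, at which 3 of the 3 values shown sit, records. The change to the unmeasured compound 4 `CC(C)N(Cc1cccc(OCCCCCC(=O)O)c1)C(=O)c1ccc(-c2cccc(C(F)(F)F)c2)cc1` is trifluoromethyl in place of acetamido on an aromatic carbon. The measured steps that bear on it all alter the same position of the shared core: a step that the two limits leave unreadable from compound 1 to compound 2, a step that the two limits leave unreadable from compound 1 to compound 3 and a step that the two limits leave unreadable from compound 2 to compound 3, and none of them has a readable size, since both ends of each lie at the limit. Going by the values given here, they show only that three different groups at this position all leave the compound at the limit, without revealing how far beyond it any of them lies. On that basis no step beyond the scatter can be expected in this assay, and compound 4 is expected to sit at the limit as well. Compound 4 is estimated at 30000 nM, in the range 15000 nM to 80000 nM. The step that the limit leaves unreadable from compound 1 to compound 4 is thus expected to be unreadable in the same way.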

Compound 4, half-maximal effective concentration: > 26000 nM
Compound 4: only a limit was reported (the forecaster's own chance of this, stated with the estimate: 85%); the middle value does not contradict the limit.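

Compound 4 reaches only a limit in this assay with > 26000 nM as its reported value. Going by these compounds alone, no step among compound 1, compound 2, compound 3 and compound 4 can be read, since all four sit at one limit: the limit of > 26000 nM in this assay, at which 4 of the 4 values shown sit. The compounds shown leave open how far beyond that limit each lies.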